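Swapping a thioether for a benzylamine on the shared core

The compounds below may be only part of what the source reports. "The series", "measured", "known", "first", "only" and "open" are said of these compounds alone.

Among the compounds with values here, compound 1, `Nc1cc(N)c2nc(-c3ccccc3)c(Sc3ccc(F)cc3)nc2c1`, is one of three compounds measured in a functional assay on IGROV-1 cells (Homo sapiens) for inhibition, read by sulforhodamine B assay, with a stated time of 48 h; a lower number here means a stronger inhibitor of growth, a higher number a weaker inhibitor of growth. In this assay compound 1 gives only a limit, < 100000 nM. Compound 2, `CCOC(=O)[C@H](CCC(=O)O)NC(=O)c1ccc(Oc2nc3cc(N)cc(N)c3nc2-c2ccccc2)cc1`, carries a longer side chain on the shared core and in this assay gives 79400 nM, a number close to that boundary. Compound 3, `CCOC(=O)[C@H](CCC(=O)O)NC(=O)c1ccc(CNc2nc3cc(N)cc(N)c3nc2-c2ccccc2)cc1`, also gives only a limit in this assay, < 100000 nM. Thus (the limit of < 100000 nM in this assay, at which 2 of the 3 values shown sit), so compound 1 cannot be placed above or below its neighbours; its value shows weak growth inhibition and nothing finer.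

Compound 4, `Nc1cc(N)c2nc(-c3ccccc3)c(NCc3ccc(F)cc3)nc2c1`, differs from compound 1 in one place: (4-fluorobenzyl)amino in place of (4-fluorophenyl)sulfanyl on an aromatic carbon. Within the data shown here, no measured pair tells how such a change shifts this assay. Compound 3, which also attaches its side chain through an amino linker, gives only a limit, which leads one to expect no step beyond the scatter from compound 1 to compound 4. The step from compound 1 to compound 4 is therefore estimated as a step that the limit leaves unreadable from compound 1 to compound 4. Compound 4 is expected to give about 90000 nM in this assay, between 40000 nM and 200000 nM, most likely reported again only as a limit.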

Compound 4, concentration for total growth inhibition: < 100000 nM
Compound 4: no number, only a limit; the forecaster's own chance of this, stated with the estimate: 60%; the middle value does not contradict the limit.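

In this assay compound 4 gives only a limit, < 100000 nM, and with compound 1 also a limit, no step from compound 1 to compound 4 can be read: the limit of < 100000 nM in this assay, at which 3 of the 4 values shown sit.

The compounds shown leave open whether (4-fluorobenzyl)amino in place of (4-fluorophenyl)sulfanyl changes growth inhibition at all, and in which direction.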